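The source may hold more compounds than are shown below. What is called first, only, known or untested is meant among the compounds shown, and "the series" means these compounds.

Measured so far:
- compound 1 `CC(C)[C@H](NC(=O)CN(c1nc(Cl)nc2[nH]cnc12)C1CC1)C(=O)O` — 30.3%
- compound 2 `CSCC[C@H](NC(=O)CN(c1nc(Cl)nc2[nH]cnc12)C1CC1)C(=O)O` — 14%
- compound 3 `CSCC[C@H](NC(=O)CN(c1ncnc2c1ncn2C1CCCCO1)C1CC1)C(=O)OCc1ccccc1` — 42.7%

Three compounds have been run in a functional assay on the whole organism (Tail, strain ICR) with Mus musculus as the target, in the tail flick test, with a stated time of 90 min, at a dose of 25 umol/kg by the oral route; on this read-out lower numbers stand for a weaker effect and higher numbers for a stronger effect at the one dose given. Compound 1 and compound 2 share one core and differ in a single place: isopropyl in place of 2-(methylsulfanyl)ethyl on a saturated chain carbon bound to an amide-type nitrogen and a carbonyl carbon. That change gave a number 16.3 percentage points higher from compound 2 to compound 1 (beyond the scatter). Compound 3 carries a different core; the difference between the two cores is not broken down here. In this assay compound 3 gives 42.7%, the highest of the three numbers, with compound 1 the nearest and compound 2 the furthest.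

Compound 4 `CC(C)[C@H](NC(=O)CN(c1ncnc2c1ncn2C1CCCCO1)C1CC1)C(=O)OCc1ccccc1` is not yet measured. It stands to compound 3 as compound 1 stands to compound 2: isopropyl in place of 2-(methylsulfanyl)ethyl on a saturated chain carbon bound to an amide-type nitrogen and a carbonyl carbon. The place of the change is the same in both pairs, so this is the same change, seen now on the core of compound 3. For the measured compounds named here, the only measured step for this change is the one from compound 2 to compound 1; with a single pair there is no way to tell whether it carries over to the other core. Taking it as the best guide, the expected step is a number 13.3 percentage points higher from compound 3 to compound 4 (beyond the scatter), resting on a number 16.3 percentage points higher from compound 2 to compound 1 (beyond the scatter) and the starting value of compound 3. Compound 4 is therefore estimated at 56%, with a range from 40% to 72%.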

Compound 4, a percentage reported as activity, at one dose (the size of the read-out at that dose, not a potency): 30.1%
Beside the measured number, compound 4's estimate is 25.9 percentage points above it; the measured number lies below the stated range.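

In this assay, isopropyl in place of 2-(methylsulfanyl)ethyl gives a number 12.6 percentage points lower from compound 3 to compound 4 (beyond the scatter), so the step measured on the first core does not carry over to the core of compound 3, in either direction or size: the same change on two cores in this assay, a number 16.3 percentage points higher (beyond the scatter) from compound 2 to compound 1 and a number 12.6 percentage points lower (beyond the scatter) from compound 3 to compound 4, 28.9 percentage points apart, beyond the scatter of two such steps
For this change, then, a step read on one core is no safe guide to the step on the other, and each core needs its own measured pair. For the compounds shown here, what this does not show is which structural difference between the two cores lies behind the reversal, or whether it would hold for any other change at this place, since only one pair exists on each core.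

The compounds shown leave open how other groups on the saturated chain carbon would behave on each core, for instance a longer chain or an amine. They also leave open whether any such group would move the read-out in the same direction on both cores.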